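Swapping the pyrazine amide of compound 1 for a methylpyridine

The source may report more compounds than this note shows. Statements on the series, on what has been measured and on what is new or still open speak of the compounds shown alone.

Compound 1 `O=C(N[C@H]1CCC[C@H](NC(=O)c2cnccn2)C1)c1cccc(Cl)c1` gives the highest number of the three measured in a functional assay on HEK293 cells for antagonist activity at metabotropic glutamate receptor 5 (Homo sapiens), read by FLIPR and calcium flux (on this read-out higher numbers stand for weaker inhibition and lower numbers for stronger inhibition), at 1370 nM. Compound 3 `O=C(NC1CCCC(NC(=O)c2ccccn2)C1)c1cccc(Cl)c1` gives 314 nM, and compound 2 `N#Cc1cccc(C(=O)N[C@@H]2CCC[C@@H](NC(=O)c3ccccn3)C2)c1` gives 231 nM; both sit well beyond the scatter from compound 1. Compound 4 `Cc1cccc(C(=O)N[C@H]2CCC[C@H](NC(=O)c3cccc(Cl)c3)C2)n1` has not been measured. It differs from compound 1 in one place: 6-methylpyridin-2-yl in place of pyrazin-2-yl on a carbonyl carbon. Among the compounds with values here, no pair of measured compounds isolates this change, so its size cannot be read directly. Given that the two lower numbers belong to compounds whose other amide is not a pyrazine, a move toward stronger inhibition is expected for compound 4, with a 5.5-fold lower number from compound 1 to compound 4 (0.74 log units; beyond the scatter) in this assay. Compound 4 is estimated at 250 nM, in a range from 70 nM to 900 nM.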

Compound 4, half-maximal inhibitory concentration: 290 nM
Compound 4: middle estimate off by 1.2-fold (0.06 log units), on the low side; low and high end bracket the measured number.
By their numbers in this assay, from the lowest: compounds 2, 4 and 3 (each within the scatter of the next); then compound 1.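

On this carbonyl carbon, the change from pyrazin-2-yl to 6-methylpyridin-2-yl now has a size of its own in this assay: a 4.7-fold lower number from compound 1 to compound 4 (0.67 log units; beyond the scatter), with the rest of compound 1 held fixed. Within the data shown here, this shows that the number responds to the group at this position, although only this one comparison supports that. No available evidence explains the step.

The step changes the ring's hetero atoms and adds a methyl at once, and the compounds shown do not separate these two changes. From the compounds shown here alone, how 6-ethylpyridin-2-yl or 6-methoxypyridin-2-yl would fare here also remains open.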